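The compounds below may be only part of what the source reports. "The series", "measured", "known", "first", "only" and "open" are said of these compounds alone.

In a functional assay on HUVEC cells (Homo sapiens) for inhibition, with a stated time of 4 days (a higher number here means a weaker inhibitor, a lower number a stronger inhibitor), compound 1 (`COc1ccc(C(C)=O)cc1COc1ccc(Cl)cc1`) gives 1200 nM and compound 2 (`COc1ccc(C#N)cc1COc1ccc(Cl)c(C)c1`) gives 1500 nM, while compound 3 (`COc1ccc(C(N)=O)cc1/C=C/c1ccccc1`) gives 2400 nM in the same test. Compound 3 therefore stands level with the other two, its value lying within the usual scatter of both. Compound 4 (`COc1ccc(C(N)=O)cc1/C=C/c1ccc(C(F)(F)F)cc1`) differs from compound 3 in one place (trifluoromethyl in place of hydrogen on an aromatic carbon), with trifluoromethyl in place of hydrogen on an aromatic carbon, para to a large group. Going by the values given here, no measured pair shows what a change of this kind does, so in this assay no step beyond the scatter is expected. The expected step (a 1.5-fold lower number from compound 3 to compound 4 (0.18 log units; within the scatter)) stays within that scatter. Compound 4 is estimated at 1600 nM (range from 500 nM to 5000 nM).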

Compound 4, half-maximal inhibitory concentration: 880 nM
Compound 4: the middle estimate sits 1.8-fold (0.26 log units) above what was measured; measured number inside the range.
By their numbers in this assay, from the lowest: compounds 4, 1, 2 and 3 (each within the scatter of the next, the first and the last beyond it).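

In this assay, trifluoromethyl in place of hydrogen on an aromatic carbon, para to a large group, gives a 2.7-fold lower number from compound 3 to compound 4 (0.44 log units; beyond the scatter). Going by these compounds alone, this is the only one-place step, and it lies beyond the scatter, so this position does respond to substitution, with a lower number on this change. No measurement on hand bears on why. The compounds shown carry no other group at this place, such as a methoxy group or an amine. As far as these compounds go, whether the step belongs to trifluoromethyl alone, and whether it would carry over to the cores of compound 1 and compound 2, stays open.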